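Methyl added to the phenyl group of compound 1

The source may report more compounds than this note shows. Statements on the series, on what has been measured and on what is new or still open speak of the compounds shown alone.

In a functional assay on HeLa cells (Homo sapiens) for antiproliferative activity, with a stated time of 5 days (a lower number here means a stronger inhibitor, a higher number a weaker inhibitor), compound 1 `CC1OC2(C=CC(=O)C=C2)N(c2nc(-c3ccc4ccccc4c3)nn2-c2ccccc2)C1=O` gives 120 nM. Compound 2 `CC1OC2(C=CC(=O)C=C2)N(c2nc(-c3cccc4ccccc34)nn2-c2ccccc2)C1=O` gives 110 nM and compound 3 `O=C1C=CC2(C=C1)OCC(=O)N2c1nc(-c2ccc3c(c2)OCCO3)nn1-c1ccccc1` gives 70 nM, and compound 1 stands within the scatter of both.

The next compound is compound 4 `Cc1ccc(-n2nc(-c3ccc4ccccc4c3)nc2N2C(=O)C(C)OC23C=CC(=O)C=C3)cc1`. Its change from compound 1 is methyl in place of hydrogen on an aromatic carbon, phenyl to 4-methylphenyl, para to a large group: methyl in place of hydrogen on an aromatic carbon.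

Within the data shown here, the only measured single-place step is a 1.1-fold lower number from compound 1 to compound 2 (0.04 log units; within the scatter), with naphthalen-1-yl in place of naphthalen-2-yl. That step lies within the scatter and concerns a different group, so it bears only indirectly on the methyl. Among the measured compounds shown here, no measured step tests a substituent on this phenyl, and the data favour neither direction. No step beyond the scatter is therefore expected in this assay. The estimated step is no change at the digits printed from compound 1 to compound 4 (within the scatter). For compound 4 the expected value is 120 nM, with an estimated range of 50 nM to 280 nM.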

Compound 4, half-maximal inhibitory concentration: 530 nM
Estimate against measurement, compound 4: 4.4-fold (0.65 log units) below, and the stated range ends below it.
By their numbers in this assay, from the lowest: compounds 3, 2 and 1 (each within the scatter of the next); then compound 4.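

In this assay, phenyl to 4-methylphenyl gives a 4.4-fold higher number from compound 1 to compound 4 (0.65 log units; beyond the scatter), the only step shown that lies beyond the scatter, while the change in the naphthalene attachment gives a 1.1-fold lower number from compound 1 to compound 2 (0.04 log units; within the scatter). This phenyl group is therefore not indifferent to substitution: one added methyl, para to a large group, is enough to weaken the compound in this assay. Nothing measured here gives a reason for the loss.

Going by these compounds, whether the loss is specific to methyl remains open, since a fluorine, a methoxy group or a hydroxyl at the same carbon could give a different result. Also unresolved is whether methyl at another carbon of this phenyl group, or the same methyl on the core of compound 2 or compound 3, would give a step of similar size.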